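A few compounds are considered here, and "the series" means these few. Any claim that something is new, unique, unknown or untested is made for them only; others in the source may bear on it.

Compound 1 `Cc1c(Cc2c(F)cccc2F)nc(N2CCCCC2)[nH]c1=O`, compound 2 `Cc1c(Cc2c(F)cccc2F)nc(N2CCCC(C)C2)[nH]c1=O` and compound 3 `Cc1c(Cc2c(F)cccc2F)nc(N2CCC(C)CC2)[nH]c1=O` share one core and differ only in the saturated ring attached to it. In an ADME assay on MT4 cells (Homo sapiens) for cytotoxicity, read by MTT assay, with a stated time of 4 days (on this read-out higher numbers stand for lower toxicity in this test and lower numbers for higher toxicity in this test), compound 1 gives > 78000 nM, which is a limit of the assay and not a number. Compound 2 gives > 75000 nM, also a limit. Compound 3 gives > 75000 nM, again a limit, so it has no exact place on the scale. All three compounds therefore stand at limits: the limit of > 75000 nM in this assay, at which 2 of the 3 values shown sit, and (the limit of > 78000 nM in this assay, at which 1 of the 3 values shown sits).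

The next compound, compound 4 `Cc1c(Cc2c(F)cccc2F)nc(N2CCCCCC2)[nH]c1=O`, has the same atoms as compound 3, joined differently: azepan-1-yl in place of 4-methylpiperidin-1-yl on an aromatic carbon. The six-membered ring gives way to a seven-membered one, with azepan-1-yl in place of 4-methylpiperidin-1-yl on an aromatic carbon.

The measured steps that bear on this are the other changes to the same ring: a step that the two limits leave unreadable from compound 1 to compound 2, a step that the two limits leave unreadable from compound 1 to compound 3 and a step that the two limits leave unreadable from compound 2 to compound 3. None has a readable size, and each of them starts and ends at a limit in this assay. No step beyond the usual scatter is therefore expected in either direction, and another limit is the likely report. The expected change is a number no higher from compound 3 to compound 4 (the limit leaves the size open). For compound 4 the estimated value is 75000 nM, with an expected range from 35000 nM to 80000 nM.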

Compound 4, half-maximal cytotoxic concentration: > 75000 nM
Compound 4 ended at the assay's limit; the forecaster's own chance of this, stated with the estimate: 85%; the middle value lies on the limit itself.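

In this assay compound 4 gives > 75000 nM, which is a limit of the assay and not a number. Its steps to compound 1, compound 2 and compound 3 cannot be read: all four values are limits. The compounds shown leave open at what concentration any of them becomes toxic to these cells, and whether their saturated rings differ at all in this test.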